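The source may report more compounds than this note shows. Statements on the series, on what has been measured and on what is new or still open speak of the compounds shown alone.

In a functional assay on OVCAR-4 cells (Homo sapiens) for inhibition (on this read-out lower numbers stand for stronger inhibition of growth and higher numbers for weaker inhibition of growth), compound 1 `COc1cc(/C=C/C(=O)c2cccc(-n3cc(-c4ccc(Cl)cc4)[nH]c3=O)c2)cc(OC)c1OC` gives 11400 nM, and compound 2 `COc1ccc(-c2cn(-c3cccc(C(=O)/C=C/c4cc(OC)c(OC)c(OC)c4)c3)c(=O)[nH]2)cc1` gives 3570 nM. For the measured compounds named here, the one step measured so far, a 3.2-fold lower number from compound 1 to compound 2 (0.50 log units; beyond the scatter), shows that the number fell when methoxy replaced chloro on the phenyl ring that hangs from the shared core. Compound 2 thus stands with the lowest of the two numbers, and its distance from compound 1 lies beyond the scatter.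

Compound 3 `COc1cc(/C=C/C(=O)c2cccc(-n3cc(-c4cc(OC)c(OC)c(OC)c4)[nH]c3=O)c2)cc(OC)c1OC` differs from compound 2 at the same phenyl ring: 3,4,5-trimethoxyphenyl in place of 4-methoxyphenyl on an aromatic carbon. Going by the values given here, this change bears some relation to the measured step, since it again adds methoxy groups to that ring, yet no measured pair shows what two further methoxy groups do at that place. The step from compound 1 to compound 2 was modest, so the expected step in this assay is modest at most, with no clear direction beyond the scatter. Compound 3 is therefore estimated to give 3000 nM, within 900 nM to 10000 nM. That estimate means an expected step of a 1.2-fold lower number from compound 2 to compound 3 (0.08 log units; within the scatter).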

Compound 3, concentration for 50% growth inhibition: 3770 nM
Compound 3: middle estimate off by 1.3-fold (0.10 log units), on the low side; the measured number falls inside the stated range.
By their numbers in this assay, from the lowest: compounds 2 and 3 (each within the scatter of the next); then compound 1.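

In this assay, replacing 4-methoxyphenyl with 3,4,5-trimethoxyphenyl on this aromatic carbon gives a 1.1-fold higher number from compound 2 to compound 3 (0.02 log units; within the scatter), so the added methoxy groups bring no change that can be told apart from the scatter, even though the incoming group is larger and has more hydrogen-bond acceptors. The new compound also shows that the earlier difference from the chloro compound is not confined to a single methoxy group: alongside a 3.2-fold lower number from compound 1 to compound 2 (0.50 log units; beyond the scatter), there is now a 3.0-fold lower number from compound 1 to compound 3 (0.48 log units; beyond the scatter), so both methoxy-bearing rings give lower numbers than the 4-chlorophenyl ring in these three compounds. Nothing available here explains why the number holds steady when the extra methoxy groups are added.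

The three compounds leave open whether one methoxy group at the 4-position is enough on its own or whether the other methoxy positions could give the same result without it, since no ring with a different methoxy arrangement appears among them. They also leave open how this position would respond to a quite different group on the phenyl ring, such as an amine, a carboxylic acid or a longer ethoxy chain.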